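The source may hold more compounds than are shown below. What is called first, only, known or untested is meant among the compounds shown, and "the series" means these compounds.

Compound 1 `COc1nc(C)c(Nc2nc(Cl)cn([C@H](COC(C)=O)C3CC3)c2=O)cc1C`: 5.3 nM
Compound 2 `COc1nc(C)c(Nc2nc(Cl)cn([C@H](COC(=O)Nc3ccccc3)C3CC3)c2=O)cc1C`: 1.5 nM
Compound 3 `COc1ccc(NC(=O)OC[C@H](C2CC2)n2cc(Cl)nc(Nc3cc(C)c(OC)nc3C)c2=O)c(C)n1`: 9.2 nM

These three were tested in an assay on frontal cortex for displacement of a labelled ligand from corticotropin-releasing factor receptor 1 (Rattus norvegicus), with a stated time of 2 h; a higher number here means a weaker inhibitor, a lower number a stronger inhibitor. Compound 1 stands second highest of the three numbers, with compound 3 nearest and compound 2 furthest from it. Compound 4 `COc1nc(C)c(Nc2nc(Cl)cn([C@H](COc3ccc(C(F)(F)F)cn3)C3CC3)c2=O)cc1C` has not yet been measured; it differs from compound 1 in one place: 5-(trifluoromethyl)pyridin-2-yl in place of acetyl on an oxygen on a saturated carbon. Among the measured compounds shown here, two measured steps bear on this change, both replacing the same acetyl with something larger: a 3.5-fold lower number from compound 1 to compound 2 (0.55 log units; beyond the scatter) and a 1.7-fold higher number from compound 1 to compound 3 (0.24 log units; within the scatter). A larger group entering at this point therefore brought a modest gain in one case and no change beyond the scatter in the other. For compound 4 a small downward step is expected, a 1.8-fold lower number from compound 1 to compound 4 (0.25 log units; within the scatter). Compound 4 is estimated at 3 nM, with a likely range from 1 nM to 12 nM.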

Compound 4, half-maximal inhibitory concentration: 1.6 nM
The estimate for compound 4 lay 1.9-fold (0.27 log units) above the measured number, within the range that was stated.
By their numbers in this assay, from the lowest: compounds 2 and 4 (each within the scatter of the next); then compounds 1 and 3 (each within the scatter of the next).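

In this assay the change gives a 3.3-fold lower number from compound 1 to compound 4 (0.52 log units; beyond the scatter) and so shows that a gain at this oxygen does not need a carbonyl in the attached group. The ring-bearing ether also sits level with the phenylcarbamoyl group in a 1.1-fold higher number from compound 2 to compound 4 (0.03 log units; within the scatter) and clearly ahead of the pyridine carbamate in a 5.8-fold lower number from compound 3 to compound 4 (0.76 log units; beyond the scatter) so a larger group can help here in more than one form. Going by these compounds, how an unsubstituted phenyl ring or a free hydroxyl on this oxygen would compare stays open. What lies behind these differences has no supporting measurement here.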